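Swapping the Amide-Bound Aryl Group: A Tolerance Forecast

The compounds below may be only part of what the source reports. "The series", "measured", "known", "first", "only" and "open" are said of these compounds alone.

compound 1 `O=C(CSc1nccn1-c1ccc(Cl)cc1)Nc1ccccc1F`: > 345000 nM
compound 2 `O=C(CSc1nccn1-c1ccc(Cl)cc1)Nc1ccccc1[N+](=O)[O-]`: > 321000 nM
compound 3 `Cc1ccc(NC(=O)CSc2nccn2-c2ccc(Cl)cc2)c(Br)c1`: 221000 nM

Three compounds sharing one core were tested in an ADME assay on MT4 cells (Homo sapiens) for cytotoxicity, read by MTT assay; a higher number here means that more compound is tolerated, a lower number that less compound is tolerated. For compound 1 the value > 345000 nM is a limit of the assay, not a number (the limit of > 345000 nM in this assay, at which 1 of the 3 values shown sits). For compound 2 the value > 321000 nM is likewise a limit (the limit of > 321000 nM in this assay, at which 1 of the 3 values shown sits). Among the measured compounds shown here, compound 3 is therefore the only one with a measured number, 221000 nM, in this assay. The step of an at least 1.5-fold lower number from compound 1 to compound 3 (0.19 log units; that floor lies within the scatter) is the only readable one; the step that the two limits leave unreadable from compound 1 to compound 2 cannot be sized.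

Compound 4 `O=C(CSc1nccn1-c1ccc(Cl)cc1)Nc1ccccc1Cl` differs from compound 3 in one place: 2-chlorophenyl in place of 2-bromo-4-methylphenyl on an amide-type nitrogen. This change sits where compound 1 and compound 3 also differ, and that step was at most modest. Compound 4 is thus expected to sit close to compound 3, with the step of a 1.4-fold higher number from compound 3 to compound 4 (0.13 log units; within the scatter) expected to lie within the scatter or slightly upward, and a limit rather than a number remains possible. The estimate for compound 4 in this assay is 300000 nM, between 180000 nM and 500000 nM.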

Compound 4, half-maximal cytotoxic concentration: > 330000 nM
Compound 4: a limit, no number (the forecaster's own chance of this, stated with the estimate: 50%); middle value at least 1.1-fold (0.04 log units) from the limit.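

In this assay compound 4, with 2-chlorophenyl on the amide-type nitrogen, reads as a limit of the assay and not as a number: the limit of > 330000 nM in this assay, at which 1 of the 4 values shown sits.

Replacing 2-bromo-4-methylphenyl with 2-chlorophenyl gives an at least 1.4-fold higher number from compound 3 to compound 4 (0.17 log units; that floor lies within the scatter), so the floor of this step does not clear the scatter, although the true step may be larger. Among the compounds shown here, compound 1, compound 2 and compound 4 all read as limits, so the steps among them, including chloro in place of fluoro or nitro, cannot be read, and compound 3 remains the only one with a measured number.

The change from compound 3 to compound 4 alters the halogen and removes the methyl together, which leaves the share of each open. Going by these compounds, how an amine or a carboxylic acid on this aryl group would read in this assay also remains open.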